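Inverting One Ring Stereocentre: Expected Solubility of Compound 4

The source may report more compounds than this note shows. Statements on the series, on what has been measured and on what is new or still open speak of the compounds shown alone.

Compound 1 `CC(C)[C@H](C[C@H]1OC(=O)NC1=O)c1ccc(-c2ccc3cccc(F)c3c2)[nH]c1=O` was measured in a physicochemical assay for solubility, in phosphate buffer, measured as kinetic solubility (a higher number here means a more soluble compound, a lower number a less soluble compound), where compound 1 gives 35400 nM. Two further compounds share its core. Compound 2 `CCC(CC)C(/C=C1\OC(=O)NC1=O)c1ccc(-c2ccc3cccc(F)c3c2)[nH]c1=O` gives 33700 nM in this assay, and compound 3 `CC(C)C(c1ccc(-c2ccc3cccc(F)c3c2)[nH]c1=O)C1SC(=O)NC1=O` gives 20100 nM in this assay. Of the three numbers, that of compound 1 is the largest, but the gap to compound 2 and the gap to compound 3 both lie within the usual scatter of repeated measurements, so the three compounds cannot be told apart on these numbers.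

Compound 4 `CC(C)[C@H](C[C@@H]1OC(=O)NC1=O)c1ccc(-c2ccc3cccc(F)c3c2)[nH]c1=O` is the next compound to be measured in this assay. Relative to compound 1, (the two compounds have the same atoms and bonds and differ only in configuration as drawn: 1 of 2 stereo elements differ; a stereocentre at a saturated ring carbon is drawn R in compound 1 and S in compound 4). Among the compounds with values here, no pair of measured compounds differing in only one place is available, so no measured step can guide the expectation for this change. On the evidence of compound 1 alone, and given that only the drawn configuration at one saturated ring carbon changes, the step from compound 1 to compound 4 in this assay is expected to be a 1.1-fold lower number from compound 1 to compound 4 (0.04 log units; within the scatter), which is not beyond the scatter in either direction. Compound 4 is therefore estimated to give 32000 nM in this assay, with a range from 16000 nM to 64000 nM.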

Compound 4, solubility: 21100 nM
Compound 4: middle estimate off by 1.5-fold (0.18 log units), on the high side, within the range that was stated.
By their numbers in this assay, from the lowest: compounds 3, 4, 2 and 1 (each within the scatter of the next).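

Inverting the stereocentre at a saturated ring carbon, drawn R in compound 1 and S in compound 4, gives the first step in this series between compounds that differ in one place, and in this assay it reads a 1.7-fold lower number from compound 1 to compound 4 (0.22 log units; within the scatter). The earlier compounds shown here offered no such pair, so this position had not been examined on its own; now the two drawn configurations at this ring carbon can be compared directly, and on this read-out they cannot be told apart. Any difference between the two numbers could come from only one structural source, and even that difference does not rise above the usual scatter of repeated measurements: the fact that compounds 1 and 4 differ only in the configuration as drawn

This single pair leaves open the other stereo element, which is drawn the same in compound 1 and compound 4, so its configuration remains unread in this assay. The compounds shown also leave open whether a carboxylic acid or an amine on the shared core would give a step beyond the scatter, as the one step read so far stays within it.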